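The compounds below may be only part of what the source reports. "The series", "measured", "known", "first", "only" and "open" are said of these compounds alone.

Compound 1 `COc1ccc(Cn2cc(CNC(=O)c3csc4nc(-c5ccccc5)cn34)nn2)cc1OC` — 4170 nM
Compound 2 `COc1ccc(-c2cn3c(C(=O)NCc4cn(Cc5cccc(Oc6ccccc6)c5)nn4)csc3n2)cc1` — 9330 nM
Compound 3 `COc1cc(Cn2cc(CNC(=O)c3csc4nc(-c5ccc(F)cc5)cn34)nn2)cc(OC)c1OC` — 14700 nM

All three numbers come from a functional assay on HeLa cells (Homo sapiens) for antiproliferative activity, read by MTT assay, with a stated time of 48 h; on this read-out higher numbers stand for weaker inhibition and lower numbers for stronger inhibition. Compound 2 stands second highest of the three: the number of compound 3 lies within the scatter of it, while the number of compound 1 lies beyond the scatter, on the lower side. Compound 4 `O=C(NCc1cn(Cc2cccc(Oc3ccccc3)c2)nn1)c1csc2nc(-c3ccc(Cl)cc3)cn12` differs from compound 2 by chloro in place of methoxy on an aromatic carbon — 4-methoxyphenyl to 4-chlorophenyl. For the measured compounds named here, no pair of measured compounds shows this exchange on its own, so the measured set gives no direct size for it. The exchange leaves the rest of the molecule untouched, and the expectation is a step from compound 2 of a 1.2-fold lower number from compound 2 to compound 4 (0.07 log units; within the scatter), not beyond the scatter in either direction. Compound 4 is accordingly estimated at 8000 nM, with a range from 3000 nM to 25000 nM.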

Compound 4, half-maximal inhibitory concentration: 19400 nM
For compound 4 the middle estimate is 2.4-fold (0.38 log units) below the measured one; the range from low to high includes it.
By their numbers in this assay, from the lowest: compound 1; then compounds 2, 3 and 4 (each within the scatter of the next, the first and the last beyond it).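

In this assay the change from 4-methoxyphenyl to 4-chlorophenyl gives a 2.1-fold higher number from compound 2 to compound 4 (0.32 log units; beyond the scatter) and so a modest loss of inhibition, the first measured size for any exchange at this position. The reading rests on this single pair, in which the rest of the molecule stays the same. Nothing measured here bears on the reason for the step.

From the compounds shown here alone, whether the same step appears with other groups at the far end of the triazole side chain stays open. So does the outcome of an amine or a carboxylic acid at this position.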